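Urea aryl swap on a thienopyrimidine-type cytotoxic series

The compounds below may be only part of what the source reports. "The series", "measured", "known", "first", "only" and "open" are said of these compounds alone.

Measured compounds and their values:
compound 1, `CN(C)CCCNc1nc(-c2ccc(NC(=O)Nc3ccc(F)cc3)cc2)nc2c(Cl)c(Cl)sc12`, 430 nM;
compound 2, `CN(C)CCNc1nc(-c2ccc(NC(=O)Nc3ccccc3)cc2)nc2ccsc12`, 620 nM;
compound 3, `CN(C)CCNc1nc(-c2ccc(NC(=O)Nc3ccc(F)cc3)cc2)nc2c(Cl)c(Cl)sc12`, 890 nM.

In a functional assay on HT-29 cells (Homo sapiens) for cytotoxicity, read by MTT assay, with a stated time of 72 h (on this read-out higher numbers stand for weaker inhibition and lower numbers for stronger inhibition), compound 3 gives the highest of the three numbers. Its step to compound 1 is beyond the scatter, a 2.1-fold higher number from compound 1 to compound 3 (0.32 log units; beyond the scatter), while its gap to compound 2 is within the scatter, so no order between compound 3 and compound 2 can be read from these two values.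

Compound 4, `CN(C)CCNc1nc(-c2ccc(NC(=O)Nc3ccc(Cl)cc3Cl)cc2)nc2c(Cl)c(Cl)sc12`, has not yet been measured in this assay. It differs from compound 3 in one place: 2,4-dichlorophenyl in place of 4-fluorophenyl on an amide-type nitrogen. Among the measured compounds shown here, none of the measured steps touches this part of the molecule. For the measured compounds named here, the only step with a number, from compound 1 to compound 3, changes the saturated chain, not the urea aryl group. Compound 2 carries a phenyl on that nitrogen but also differs from compound 3 in its core, so its value shows only that such variation, taken together, stayed within the scatter of compound 3.

Going by the values given here, with no bearing step, the expectation for compound 4 is no change beyond the scatter in this assay, with a wide range in either direction: compound 4 is estimated at 900 nM, between 300 nM and 2700 nM, a step of a 1.0-fold higher number from compound 3 to compound 4 (0.00 log units; within the scatter).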

Compound 4, half-maximal inhibitory concentration: 1280 nM
The estimate for compound 4 lay 1.4-fold (0.15 log units) below the measured number; low and high end bracket the measured number.
By their numbers in this assay, from the lowest: compounds 1, 2, 3 and 4 (each within the scatter of the next, the first and the last beyond it).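

In this assay, among the compounds shown here, the step of a 1.4-fold higher number from compound 3 to compound 4 (0.16 log units; within the scatter) is the first single-place comparison at the aryl group on the amide-type nitrogen, since the only earlier step with a number changed the saturated chain. It shows that, with the chain and the core held as in compound 3, 2,4-dichlorophenyl can stand in place of 4-fluorophenyl on this nitrogen without a difference that can be told from the scatter of repeated measurements, so this one swap gives no sign that the read-out depends on which of these two halogenated phenyl groups is present. Nothing at hand gives a measured property that would bear on this result.

What the compounds shown leave open is whether a different kind of group on this nitrogen, such as a pyridyl ring, a phenyl carrying a carboxylic acid or a phenyl carrying an amine, would move the number beyond the scatter. As far as these compounds go, it also remains open whether the step seen at the saturated chain would hold with 2,4-dichlorophenyl on the urea, as the chain of compound 1 has been seen here only with 4-fluorophenyl.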